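Swapping a Small Ring for a Larger Ether-Bearing Ring

The source may report more compounds than this note shows. Statements on the series, on what has been measured and on what is new or still open speak of the compounds shown alone.

Compound 3 `CC(C(=O)NCc1ccc(C(F)(F)F)nc1N1CCCC1)c1ccc(NS(C)(=O)=O)c(F)c1` gives 211 nM in a functional assay on CHO-K1 cells for antagonist activity at transient receptor potential cation channel subfamily V member 1 (Homo sapiens), read by FLIPR (on this read-out higher numbers stand for weaker inhibition and lower numbers for stronger inhibition), the lowest of the three numbers in hand; compound 2 `CC(C(=O)NCc1ccc(C(F)(F)F)nc1NCc1ccc(Cl)cc1)c1ccc(NS(C)(=O)=O)c(F)c1` gives 414 nM, a gap within the scatter, while compound 1 `CC1CCC(Nc2nc(C(F)(F)F)ccc2CNC(=O)C(C)c2ccc(NS(C)(=O)=O)c(F)c2)CC1` gives 1130 nM, the highest of the three. Compound 4 `CCCCOC1CCN(c2nc(C(F)(F)F)ccc2CNC(=O)C(C)c2ccc(NS(C)(=O)=O)c(F)c2)CC1` differs from compound 3 in one place: a group of 11 heavy atoms (9 carbon, 1 nitrogen, 1 oxygen; one six-membered non-aromatic ring with 1 hetero atom) in place of a group of 5 heavy atoms (4 carbon, 1 nitrogen; one five-membered non-aromatic ring with 1 hetero atom), on an aromatic carbon. The steps that touch this aromatic carbon are a 5.4-fold lower number from compound 1 to compound 3 (0.73 log units; beyond the scatter) and a 2.0-fold lower number from compound 2 to compound 3 (0.29 log units; within the scatter), both moving toward lower numbers as the amino-linked groups gave way to the ring. Compound 4 keeps a ring but a larger one, and the six-membered ring group of compound 1 went with the highest number, so a small rise is expected, a 1.7-fold higher number from compound 3 to compound 4 (0.22 log units; within the scatter). Compound 4 is therefore estimated at 350 nM, with a range from 120 nM to 1000 nM.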

Compound 4, half-maximal inhibitory concentration: 28.2 nM
For compound 4 the middle estimate is 12-fold (1.09 log units) above the measured one; the measured number lies below the stated range.
By their numbers in this assay, from the lowest: compound 4; then compounds 3 and 2 (each within the scatter of the next); then compound 1.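

At this aromatic carbon, a much larger group can give a lower number in this assay (the ether-bearing six-membered ring gives a 7.5-fold lower number from compound 3 to compound 4 (0.87 log units; beyond the scatter)). The same group also gives lower numbers against the amino-linked groups (a 15-fold lower number from compound 2 to compound 4 (1.17 log units; beyond the scatter); a 40-fold lower number from compound 1 to compound 4 (1.60 log units; beyond the scatter)), so group size alone does not set the order. No measurement here explains this gain. The compounds leave open whether the gain comes from the six-membered ring or from its butoxy chain, and how a methoxy chain or a carboxylic acid there would read.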